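Replacing the Benzoyl Phenyl with a Piperazine Amide

A few compounds are considered here, and "the series" means these few. Any claim that something is new, unique, unknown or untested is made for them only; others in the source may bear on it.

Measured compounds:
- compound 1 `CC(C)(C)c1cc(NC(=O)[C@@H]2CCCCN2Cc2ccc(Cl)cc2)no1`: in an ADME assay (liver) for metabolic stability, with Liver microsome (Homo sapiens) as the target, read by LC-MS, using microsomes and NADPH, tested at 1 uM (on this read-out lower numbers stand for a shorter-lived compound and higher numbers for a longer-lived compound), compound 1 gives 0.15 h
- compound 2 `CC(C)(C)c1cc(NC(=O)[C@@H]2CCCCN2C2CC2)no1`: in this assay compound 2 gives 0.183 h
- compound 3 `CC(C)(C)c1cc(NC(=O)[C@@H]2CCCCN2C(=O)c2ccccc2)no1`: in this assay compound 3 gives 0.683 h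

All three share the same core and differ only in the group attached to the amine nitrogen in the ring. Compound 3 gives the highest number of the three; its steps to the others are both beyond the scatter, the nearer being a 3.7-fold higher number from compound 2 to compound 3 (0.57 log units; beyond the scatter) and the further a 4.6-fold higher number from compound 1 to compound 3 (0.66 log units; beyond the scatter), whereas a 1.2-fold higher number from compound 1 to compound 2 (0.09 log units; within the scatter) is within the scatter.

Compound 4 `CCC(=O)N1CCN(C(=O)N2CCCC[C@H]2C(=O)Nc2cc(C(C)(C)C)on2)CC1` keeps the carbonyl on that nitrogen but changes what sits on the carbonyl carbon: 4-propanoylpiperazin-1-yl in place of phenyl on a carbonyl carbon.

Going by the values given here, no measured step touches this position, so the expectation rests only indirectly on the measured compounds. The steps from compound 1 and compound 2 to compound 3 show that the carbonyl-bearing substituent is associated with the longer half-life, and compound 4 retains it. Because the steps of a 4.6-fold higher number from compound 1 to compound 3 (0.66 log units; beyond the scatter) and a 3.7-fold higher number from compound 2 to compound 3 (0.57 log units; beyond the scatter) speak only to the carbonyl itself and not to what stands on it, the expected step of a 1.3-fold higher number from compound 3 to compound 4 (0.12 log units; within the scatter) is estimated as small, within or close to the scatter, in either direction. Compound 4 is estimated to give 0.9 h, with a range from 0.35 h to 2.3 h.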

Compound 4, half-life: > 2 h
Compound 4 was reported as a limit; the forecaster's own chance of this, stated with the estimate: 5%; middle value at least 2.2-fold (0.34 log units) from the limit.
By their numbers in this assay, from the lowest: compounds 1 and 2 (each within the scatter of the next); then compound 3. At a limit, above all of these: compound 4.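

In this assay compound 4 gives > 2 h, and this is a limit of the assay, not a number. The earlier compounds shown here changed only the group on the amine nitrogen in the ring, so they could not show whether the group on the carbonyl carbon matters; putting 4-propanoylpiperazin-1-yl in place of phenyl now gives an at least 2.9-fold higher number from compound 3 to compound 4 (0.46 log units; beyond the scatter), which shows that this place does affect the half-life and that the phenyl is not needed to reach the half-life of compound 3. The size of this step is only a lower bound: the limit of > 2 h in this assay, at which 1 of the 4 values shown sits.

The compounds shown do not separate the two parts of the entering group, since the piperazine ring and the propanoyl on it arrive together, and a simple amine on the carbonyl carbon, or an acetyl or a longer acyl chain in place of propanoyl, would help show which part goes with the longer half-life. Going by these compounds, how far compound 4 lies past the limit also remains open.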